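Urea to benzamide at the anilide of compound 1

The source may report more compounds than this note shows. Statements on the series, on what has been measured and on what is new or still open speak of the compounds shown alone.

Measured compounds and their numbers in a functional assay on HOP-92 cells (Homo sapiens) for inhibition, read by sulforhodamine B assay, with a stated time of 48 h; on this read-out lower numbers stand for stronger inhibition and higher numbers for weaker inhibition:
compound 1 `COc1cc(-c2nn(-c3cccc(NC(=O)Nc4ccc(Cl)c(Cl)c4)c3)cc2-c2ccncc2)ccc1Cl` — 150 nM
compound 2 `O=C(Nc1cccc(-n2cc(-c3ccncc3)c(-c3ccc(Cl)c(O)c3)n2)c1)Nc1ccc(Cl)c(Cl)c1` — 680 nM
compound 3 `O=C(Nc1cccc(-n2cc(-c3ccncc3)c(-c3ccc(Cl)c(O)c3)n2)c1)Nc1cc(C(F)(F)F)cc(C(F)(F)F)c1` — 340 nM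

Compound 1 gives the lowest number of the three in this assay. Compound 3 comes nearest to it, and compound 2 is furthest. For the measured compounds named here, the one single-point step that is measured is a 4.5-fold higher number from compound 1 to compound 2 (0.66 log units; beyond the scatter); it concerns the oxygen on the aromatic ring and touches neither the urea nor its distal aryl. Compounds 2 and 3 differ in that distal aryl, and their two values are as given above; no step is computed for that pair.

Compound 4 `COc1cc(-c2nn(-c3cccc(NC(=O)c4ccccc4)c3)cc2-c2ccncc2)ccc1Cl` is the unmeasured one. Its change from compound 1 is phenyl in place of (3,4-dichlorophenyl)amino on a carbonyl carbon; cut one bond further out it reads (3,4-dichlorophenyl)carbamoyl to benzoyl. Going by the values given here, no measured step bears on this change directly: the measured step shows how far the series moves on a small change elsewhere, but the only compounds carrying a changed distal aryl both keep the urea, so the loss of that nitrogen and its dichlorophenyl is untested here. Compound 4 is therefore estimated to move in the direction of a higher number, a 10-fold higher number from compound 1 to compound 4 (1.00 log units; beyond the scatter), with wide uncertainty. The expected value for compound 4 is 1500 nM, within 400 nM to 6000 nM.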

Compound 4, half-maximal inhibitory concentration: 320 nM
For compound 4 the middle estimate is 4.7-fold (0.67 log units) above the measured one; measured number outside the range, below it.
By their numbers in this assay, from the lowest: compound 1; then compounds 4, 3 and 2 (each within the scatter of the next, the first and the last beyond it).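

In this assay, phenyl in place of (3,4-dichlorophenyl)amino on the carbonyl carbon gives a 2.1-fold higher number from compound 1 to compound 4 (0.33 log units; beyond the scatter), a modest step. This is the first change shown that removes the urea itself rather than altering a group elsewhere on the molecule or the distal aryl while keeping the urea. Compound 4 shows that a benzamide lacking the urea's outer nitrogen and both chlorine atoms still reaches 320 nM, so neither feature is required for a sub-micromolar number in this series, although the loss remains beyond the scatter. Nothing available explains the size of this step.

Because the outer nitrogen and the two chlorine atoms leave in a single step, their separate contributions remain unresolved; a 3,4-dichlorobenzoyl group on the same amide nitrogen and a phenylamino group on the same carbonyl carbon would separate them. Also open, on these data alone, is how far the benzoyl ring can carry other groups, such as a dimethylamino group, a carboxylic acid or a longer alkyl chain.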